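Swapping an Amide Aryl Group on Two Different Cores

A few compounds are considered here, and "the series" means these few. Any claim that something is new, unique, unknown or untested is made for them only; others in the source may bear on it.

Compound 1 `COc1ccc(NC(=O)/C=C/C(=O)N2C/C(=C\c3ccc([N+](=O)[O-])cc3)C(=O)/C(=C/c3ccc([N+](=O)[O-])cc3)C2)cc1`: 940 nM
Compound 2 `Cc1ccc(NC(=O)/C=C/C(=O)N2C/C(=C\c3ccc([N+](=O)[O-])cc3)C(=O)/C(=C/c3ccc([N+](=O)[O-])cc3)C2)cc1C`: 660 nM
Compound 3 `Cc1ccc(NC(=O)/C=C/C(=O)N2C/C(=C\c3ccccc3)C(=O)/C(=C/c3ccccc3)C2)cc1C`: 7900 nM

All three were tested in a functional assay on Molt4/C8 cells (Homo sapiens) for cytotoxicity; a higher number here means a weaker inhibitor, a lower number a stronger inhibitor. Compound 2 and compound 1 share one core and differ only by 4-methoxyphenyl in place of 3,4-dimethylphenyl on an amide-type nitrogen; the step of a 1.4-fold higher number from compound 2 to compound 1 (0.15 log units; within the scatter) is within the scatter. Compound 3 is built on another core, and the difference between the two cores is not broken down here; in this assay compound 3 gives the highest number of the three, beyond the scatter from both others.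

Compound 4 `COc1ccc(NC(=O)/C=C/C(=O)N2C/C(=C\c3ccccc3)C(=O)/C(=C/c3ccccc3)C2)cc1` has not been measured. It differs from compound 3 by 4-methoxyphenyl in place of 3,4-dimethylphenyl on an amide-type nitrogen, the same change as from compound 2 to compound 1, at the same place. Because the earlier step was a 1.4-fold higher number from compound 2 to compound 1 (0.15 log units; within the scatter), the step now expected is a 1.3-fold higher number from compound 3 to compound 4 (0.10 log units; within the scatter). Compound 4 is therefore estimated at 10000 nM, expected between 5000 nM and 22000 nM.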

Compound 4, half-maximal inhibitory concentration: 1100 nM
The estimate for compound 4 lay 9.1-fold (0.96 log units) above the measured number; the measured number lies below the stated range.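

In this assay, putting 4-methoxyphenyl in place of 3,4-dimethylphenyl on the amide-type nitrogen gives a 7.2-fold lower number from compound 3 to compound 4 (0.86 log units; beyond the scatter). The result of this change therefore did not carry from one core to the other, as the two steps differ by more than the scatter: the same change on two cores in this assay, a 1.4-fold higher number (0.15 log units; within the scatter) from compound 2 to compound 1 and a 7.2-fold lower number (0.86 log units; beyond the scatter) from compound 3 to compound 4, 10-fold (1.01 log units) apart, beyond the scatter of two such steps This shows that, for these two pairs, the size of the step depends on the core, but it does not show what in the cores sets the difference or how the change would behave on a third core.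

From the compounds shown here alone, it remains open how an aryl group carrying a chlorine atom or a carboxylic acid would compare on these two cores. Two pairs also cannot establish a rule for the wider series.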